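A Methylsulfonyl Group Added to the Core of Compound 1

The source may report more compounds than this note shows. Statements on the series, on what has been measured and on what is new or still open speak of the compounds shown alone.

Compound 1 `CN(C)CC[C@H](CSc1ccccc1)Nc1ccc(S(=O)(=O)NC(=O)c2ccc(N3CCN(Cc4ccccc4-c4ccc(Cl)cc4)CC3)cc2)cc1`: 14 nM
Compound 2 `CN(C)CC[C@H](CSc1ccccc1)Nc1ccc(S(=O)(=O)NC(=O)c2ccc(N3CCN(CC4=C(c5ccc(Cl)cc5)CCC(C)(C)C4)CC3)cc2)cc1[N+](=O)[O-]`: 1.4 nM
Compound 3 `CN(C)CC[C@H](CSc1ccccc1)Nc1ccc(S(=O)(=O)NC(=O)c2ccc(N3CCN(CC4=C(c5ccc(Cl)cc5)CCC4)CC3)cc2)cc1[N+](=O)[O-]`: < 1 nM

All three were tested in an assay on isolated protein for displacement of a labelled ligand from Bcl2-associated agonist of cell death (Homo sapiens), read by fluorescence polarization; a lower number here means a stronger inhibitor, a higher number a weaker inhibitor. Compound 1 gives 14 nM, the highest of the two numbers, and compound 2 gives 1.4 nM, a gap well beyond the usual scatter. For compound 3 the result is a limit of the assay, not a number: the limit of < 1 nM in this assay, at which 1 of the 3 values shown sits.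

Compound 4 `CN(C)CC[C@H](CSc1ccccc1)Nc1ccc(S(=O)(=O)NC(=O)c2ccc(N3CCN(Cc4ccccc4-c4ccc(Cl)cc4)CC3)cc2)cc1S(C)(=O)=O` has not yet been measured. It differs from compound 1 in one place: methylsulfonyl in place of hydrogen on an aromatic carbon. Going by the values given here, no measured pair among the three compounds shows this exact change, so the expectation rests on compound 1 alone. Compound 4 is expected to give a lower number than compound 1, a step of a 3.5-fold lower number from compound 1 to compound 4 (0.54 log units; beyond the scatter). Compound 4 is estimated at 4 nM, with a likely range from 1 nM to 15 nM.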

Compound 4, inhibition constant: < 1 nM
Compound 4 ended at the assay's limit; the forecaster's own chance of this, stated with the estimate: 15%; middle value at least 4.0-fold (0.60 log units) away from the limit.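

In this assay, a change at this one position of the shared core now stands alone: methylsulfonyl in place of hydrogen on an aromatic carbon, ortho to a large group and meta to a large group, gives an at least 14-fold lower number from compound 1 to compound 4 (1.14 log units; beyond the scatter). So this position accepts a group of this size, and the change brings a large gain in binding. Compound 4 gives < 1 nM, which is a limit and not a number, so the step shows only a minimum size: the limit of < 1 nM in this assay, at which 2 of the 4 values shown sit.

From the compounds shown here alone, how far compound 4 lies past that limit remains open. So does how an amine or a trifluoromethyl group at this position would compare with methylsulfonyl.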